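The source may hold more compounds than are shown below. What is called first, only, known or untested is meant among the compounds shown, and "the series" means these compounds.

Working notes on the series, all read in a functional assay on L1210 cells (Mus musculus) for antiproliferative activity; a higher number here means a weaker inhibitor, a lower number a stronger inhibitor.

Compound 1 `Oc1cccc2nccc(O)c12` gives > 40000 nM, which is a limit of the assay. Compound 2 `COc1ccc(OC)c2c(O)ccnc12`, which carries methoxy on the shared core, gives > 40000 nM, also a limit. Compound 3 `Cc1ccc(O)c2c(O)ccnc12` gives > 40000 nM, again only a limit. Among the compounds with values here, compound 3 therefore has no number to stand on, and the series so far shows only (the limit of > 40000 nM in this assay, at which 3 of the 3 values shown sit).

The next compound is compound 4 `COc1ccc(C)c2nccc(O)c12`, which differs from compound 3 by methyl in place of hydrogen on an oxygen on an aromatic ring, so that hydroxy becomes methoxy. Within the data shown here, the only measured step, a step that the two limits leave unreadable from compound 1 to compound 3, is a different change and gives no size to carry over. Compound 2 gives the closest hint, since methoxy on the core there still leaves > 40000 nM as a limit. No real gain in this assay is therefore expected, and the most likely result is another limit. The expected step is a number no higher from compound 3 to compound 4 (the limit leaves the size open), and it stays within the scatter. The estimate for compound 4 is 40000 nM, with an expected range of 20000 nM to 80000 nM.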

Compound 4, half-maximal inhibitory concentration: > 40000 nM
Compound 4 gave a limit, no number; the forecaster's own chance of this, stated with the estimate: 85%; the middle value sits exactly at the limit.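

Compound 4 gives > 40000 nM, again only a limit, so its steps from compound 3 and from compound 2 cannot be read. The compounds shown leave open whether any change on the shared core gives a readable number in this assay; the series so far shows only this: the limit of > 40000 nM in this assay, at which 4 of the 4 values shown sit.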